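The source may report more compounds than this note shows. Statements on the series, on what has been measured and on what is new or still open speak of the compounds shown alone.

Among the compounds with values here, in a functional assay on Jurkat cells (Homo sapiens) for antiproliferative activity, read by MTT assay (on this read-out lower numbers stand for stronger inhibition and higher numbers for weaker inhibition), compound 1 (`COc1cccc(/C=C2\CCc3cc(OC)c(OC)cc3C2=O)c1`) gives 5000 nM, the lower of the two numbers so far, while compound 2 (`COc1cc2c(cc1OC)C(=O)/C(=C/c1cccc(C)c1)CC2`) gives 17000 nM. Compound 3 (`COc1cc(/C=C2\CCc3cc(OC)c(OC)cc3C2=O)cc(OC)c1`) keeps the core of compound 1 and differs by methoxy in place of hydrogen on an aromatic carbon. Within the data shown here, the only measured step, a 3.4-fold higher number from compound 1 to compound 2 (0.53 log units; beyond the scatter), is modest and swaps methoxy for methyl, so it does not test an added methoxy. No step beyond the scatter is therefore expected in this assay. For compound 3 the estimated value is 4000 nM, with an expected range of 1300 nM to 14000 nM. The expected step is a 1.3-fold lower number from compound 1 to compound 3 (0.10 log units; within the scatter).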

Compound 3, half-maximal inhibitory concentration: 5000 nM
The estimate for compound 3 lay 1.3-fold (0.10 log units) below the measured number, within the range that was stated.
By their numbers in this assay, from the lowest: compounds 1 and 3 (each within the scatter of the next); then compound 2.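

In this assay, methoxy in place of hydrogen on an aromatic carbon, meta to a large group and meta to a methoxy group, gives no change at the digits printed from compound 1 to compound 3 (within the scatter). This position therefore tolerates an added methoxy in this assay, whereas the earlier step only replaced the existing methoxy with methyl. Nothing available accounts for this flat result.

As far as these compounds go, whether an amine, a hydroxyl or a carboxylic acid at this position would also leave the number within the scatter remains open. From the compounds shown here alone, whether a longer chain such as butoxy would do so is equally open.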